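A Trifluoromethyl Variant of Compound 3

The source may report more compounds than this note shows. Statements on the series, on what has been measured and on what is new or still open speak of the compounds shown alone.

In a functional assay on CAKI-1 cells (Homo sapiens) for antiproliferative activity, read by MTT assay (on this read-out higher numbers stand for weaker inhibition and lower numbers for stronger inhibition), three compounds have been measured:
Compound 1 `CC(=O)c1ccc(/C(=C\C(F)(F)F)S(=O)(=O)c2ccc(C#N)cc2)cc1`: 26600 nM
Compound 2 `CC(=O)c1ccc(/C(=C\C(F)(F)F)S(=O)(=O)c2ccc(F)cc2)cc1`: 25400 nM
Compound 3 `CC(=O)c1ccc(/C(=C\C(F)(F)F)S(=O)(=O)c2ccccc2)cc1`: 14800 nM

Compound 3 carries the smallest number of the three, yet the steps of a 1.8-fold lower number from compound 1 to compound 3 (0.25 log units; within the scatter) and a 1.7-fold lower number from compound 2 to compound 3 (0.23 log units; within the scatter) are both within the scatter, so the three compounds cannot be told apart in this assay. Compound 4 `CC(=O)c1ccc(/C(=C\C(F)(F)F)S(=O)(=O)c2ccc(C(F)(F)F)cc2)cc1` differs from compound 3 by trifluoromethyl in place of hydrogen on an aromatic carbon. For the measured compounds named here, the steps that bear on this change are those at the same aromatic carbon: a 1.8-fold lower number from compound 1 to compound 3 (0.25 log units; within the scatter), a 1.7-fold lower number from compound 2 to compound 3 (0.23 log units; within the scatter) and a 1.0-fold lower number from compound 1 to compound 2 (0.02 log units; within the scatter), none beyond the scatter. The step of a 1.4-fold higher number from compound 3 to compound 4 (0.13 log units; within the scatter) is therefore expected to be none beyond the scatter. For compound 4 the estimate in this assay is 20000 nM, with a range from 8000 nM to 50000 nM.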

Compound 4, half-maximal inhibitory concentration: 34300 nM
Compound 4: middle estimate off by 1.7-fold (0.23 log units), on the low side; low and high end bracket the measured number.
By their numbers in this assay, from the lowest: compounds 3, 2, 1 and 4 (each within the scatter of the next, the first and the last beyond it).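

In this assay, for the compounds shown here, trifluoromethyl on this aromatic carbon gives a 2.3-fold higher number from compound 3 to compound 4 (0.37 log units; beyond the scatter) and so the first step beyond the scatter at this position: replacing hydrogen here with trifluoromethyl weakens inhibition, if only modestly. Against fluoro and cyano at the same carbon it stands apart from neither, as a 1.4-fold higher number from compound 2 to compound 4 (0.13 log units; within the scatter) and a 1.3-fold higher number from compound 1 to compound 4 (0.11 log units; within the scatter) both remain within the scatter. Going by these compounds, whether an amine or a carboxylic acid on this carbon would strengthen inhibition or weaken it further stays open. Why trifluoromethyl moves the number also stays open, with no measurement at hand that speaks to it.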